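Chloro to Bromo on the Aryl Ring of Compound 3

The source may report more compounds than this note shows. Statements on the series, on what has been measured and on what is new or still open speak of the compounds shown alone.

Three compounds share a thiocarbonyl-bearing core with a nitrile and an imine linking a 4-chlorophenyl group. Compound 1 `CCCn1c(/N=C/c2ccc(Cl)cc2)c(C#N)sc1=S` gives 2.32 nM in an assay on HEK293 cells for displacement of a labelled ligand from adenosine receptor A1 (Homo sapiens), read by scintillation counting, with a stated time of 60 min; on this read-out lower numbers stand for stronger inhibition and higher numbers for weaker inhibition. Compound 2 `CCCCn1c(/N=C/c2ccc(Cl)cc2)c(C#N)sc1=S` gives 24600 nM, a step of an 11000-fold higher number from compound 1 to compound 2 (4.03 log units; beyond the scatter). Compound 3 `N#Cc1sc(=S)n(-c2ccccc2)c1/N=C/c1ccc(Cl)cc1` gives 413 nM, which is a 180-fold higher number from compound 1 to compound 3 (2.25 log units; beyond the scatter) and a 60-fold lower number from compound 2 to compound 3 (1.77 log units; beyond the scatter); compound 3 thus stands second highest of the three. Compound 4 `N#Cc1sc(=S)n(-c2ccccc2)c1/N=C/c1ccc(Br)cc1` differs from compound 3 by bromo in place of chloro on an aromatic carbon. Going by the values given here, none of the measured steps touches this position: all of them change the group on the aromatic nitrogen, and the 4-chlorophenyl group is kept in every measured compound. Among the compounds with values here, with no measured step bearing on it, the author expects for compound 4 no change beyond the scatter, a step of a 1.0-fold lower number from compound 3 to compound 4 (0.01 log units; within the scatter), and estimates 400 nM with a range from 130 nM to 1200 nM.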

Compound 4, inhibition constant: 186 nM
The estimate for compound 4 lay 2.2-fold (0.33 log units) above the measured number; measured number inside the range.
By their numbers in this assay, from the lowest: compound 1; then compound 4; then compound 3; then compound 2.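

Going by these compounds alone, compound 4 shows that the halogen on the aryl ring, kept constant in the earlier compounds, can shift the number: 4-bromophenyl in place of 4-chlorophenyl gives a 2.2-fold lower number from compound 3 to compound 4 (0.35 log units; beyond the scatter) in this assay. This modest step is much smaller than the change on the aromatic nitrogen, a 180-fold higher number from compound 1 to compound 3 (2.25 log units; beyond the scatter). Nothing available here explains the shift.

The compounds shown leave open how fluoro, iodo or an amine would read at this place. They also leave open whether bromo gives a similar step when propyl, as in compound 1, sits on the aromatic nitrogen.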